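Swapping One Aromatic Group on a Carbonyl Carbon

This account rests on a few compounds, and the source may have more. Where it says the series, first, only, none or still open, it means among the compounds named here.

Among the compounds with values here, only two compounds have numbers so far in an ADME assay on SH-SY5Y cells (Homo sapiens) for cytotoxicity, read by MTT assay, with a stated time of 72 h; a higher number here means a weaker inhibitor, a lower number a stronger inhibitor. Compound 1 (`O=C(CN1CCN(C(=O)c2cccc(Cl)c2)CC1)N1CCN(CCCc2c[nH]c3ccc(F)cc23)CC1`) gives 59800 nM. Compound 2 (`COc1ccc(C(=O)N2CCN(CC(=O)N3CCN(CCCc4c[nH]c5ccc(OC)cc45)CC3)CC2)cc1`) gives 190000 nM, the higher of the two numbers, and its gap to compound 1 lies beyond the usual scatter.

The next compound to be tested is compound 3 (`COc1ccc2[nH]cc(CCCN3CCN(C(=O)CN4CCN(C(=O)c5cccc(Cl)c5)CC4)CC3)c2c1`). It has 3-chlorophenyl in place of 4-methoxyphenyl on a carbonyl carbon. Within the data shown here, compound 1 and compound 2 differ in more than one place, so no measured pair shows the effect of this change alone. Among the measured compounds shown here, the one clue is that compound 1 also carries 3-chlorophenyl, and it gives 59800 nM. That points towards a lower number, but only part of the gap seen in that pair can be expected to appear here. The estimated change is a 1.8-fold lower number from compound 2 to compound 3 (0.26 log units; within the scatter), a modest move that may not clear the scatter. For compound 3 the estimated value is 105000 nM, with an expected range of 45000 nM to 220000 nM.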

Compound 3, half-maximal inhibitory concentration: > 200000 nM
Compound 3: a limit, no number (the forecaster's own chance of this, stated with the estimate: 10%); middle value at least 1.9-fold (0.27 log units) away from the limit.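

Compound 3 carries a limit of the assay and not a number: the limit of > 200000 nM in this assay, at which 1 of the 3 values shown sits.

At the carbonyl carbon, 3-chlorophenyl in place of 4-methoxyphenyl gives an at least 1.0-fold higher number from compound 2 to compound 3 (0.02 log units; that floor lies within the scatter) and so shows no drop towards the lower number that compound 1 gave, although the floor of this step cannot separate the change from no change at all. The second step is the more telling one, since compound 1 and compound 3 share 3-chlorophenyl and differ only in methoxy in place of fluoro on an aromatic carbon, and this gives an at least 3.3-fold higher number from compound 1 to compound 3 (0.52 log units; beyond the scatter), which is clear of the scatter. Within this pair, then, the lower number of compound 1 goes with fluoro on that aromatic carbon, and 3-chlorophenyl alone does not bring it.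

As far as these compounds go, how far the true value of compound 3 lies past its limit stays unknown, so the full size of both steps remains open. Also open, from the compounds shown here alone, is what an amine or a nitrile would do on that aromatic carbon, and whether a longer chain on the carbonyl carbon would move the number at all.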